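Swapping the nitrophenyl for methylphenyl on the sulfonyl sulfur

The source may report more compounds than this note shows. Statements on the series, on what has been measured and on what is new or still open speak of the compounds shown alone.

Measured so far in a functional assay on PC-3 cells (Homo sapiens) for inhibition; on this read-out lower numbers stand for stronger inhibition and higher numbers for weaker inhibition:
compound 1 `COc1cc2nc(N3CCN(S(=O)(=O)c4ccccc4[N+](=O)[O-])CC3)nc(N)c2cc1OC` gives 35000 nM
compound 2 `COc1cc2nc(N3CCN(S(=O)(=O)c4cccc([N+](=O)[O-])c4)CC3)nc(N)c2cc1OC` gives 32000 nM

Among the compounds with values here, compound 2 stands at the lowest of the two numbers in this assay, but its nearest neighbour is compound 1, and the only measured step, a 1.1-fold lower number from compound 1 to compound 2 (0.04 log units; within the scatter), lies within the scatter, so the two values show no difference that can be relied on. Compound 3 `COc1cc2nc(N3CCN(S(=O)(=O)c4ccc(C)cc4)CC3)nc(N)c2cc1OC` is the next member of the series; it differs from compound 2 in a single place: 4-methylphenyl in place of 3-nitrophenyl on a sulfonyl sulfur. Within the data shown here, no measured step involves a 4-methylphenyl group, so the one step in hand, which moved a nitro group around the ring without effect beyond the scatter, is the only guide. On that basis the expected step is a 1.1-fold lower number from compound 2 to compound 3 (0.03 log units; within the scatter), with no direction favoured beyond the scatter. For compound 3 the estimate in this assay is therefore 30000 nM, with a range from 8000 nM to 110000 nM.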

Compound 3, half-maximal inhibitory concentration: 30000 nM
For compound 3 middle estimate and measured number coincide at the digits printed; measured number inside the range.
By their numbers in this assay, from the lowest: compounds 3, 2 and 1 (each within the scatter of the next).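

In this assay, the 4-methylphenyl group on the sulfonyl sulfur gives a 1.1-fold lower number from compound 2 to compound 3 (0.03 log units; within the scatter) and also a 1.2-fold lower number from compound 1 to compound 3 (0.07 log units; within the scatter) in the comparison with the other nitrophenyl compound. The earlier pair differed only in how the nitrophenyl group was substituted, whereas compound 3 shows that at this position the nitro group itself can give way to a methyl group with no difference beyond the scatter. No measurement is available that bears on why these three numbers agree.

All three compounds carry a substituted phenyl on the sulfonyl sulfur, so this position is explored only within that narrow range. On these data alone, whether an amine or a carboxylic acid on that phenyl, or a longer alkyl chain in its place, would shift the number beyond the scatter remains open.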